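The source may hold more compounds than are shown below. What is called first, only, known or untested is meant among the compounds shown, and "the series" means these compounds.

Working notes on the series. In a physicochemical assay for metabolic stability, read by HPLC, in phosphate buffer, at pH 7.4, tested at 10 uM (a higher number here means that the compound lasts longer, a lower number that the compound disappears faster), compound 1 `O=C(c1ccccc1)c1ccc2c(c1)oc(=O)n2C(=O)NCCCCc1ccccc1` gives 1.63 h. Compound 2 `O=C(NCCCCc1ccccc1)n1c(=O)oc2cc(Cl)ccc21` carries chloro in place of benzoyl on an aromatic carbon and in this assay compound 2 gives 0.967 h, a step of a 1.7-fold lower number from compound 1 to compound 2 (0.23 log units; within the scatter). Compound 3 `O=C(c1ccc(Cl)cc1)c1ccc2c(c1)oc(=O)n2C(=O)NCCCCc1ccccc1` carries chloro in place of hydrogen on an aromatic carbon; compound 3 gives 4.57 h, a step of a 2.8-fold higher number from compound 1 to compound 3 (0.45 log units; beyond the scatter), and the step of a 4.7-fold higher number from compound 2 to compound 3 (0.67 log units; beyond the scatter) follows.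

Compound 4 `O=C(NCCCCc1ccccc1)n1c(=O)oc2cc(Cl)c(Cl)cc21` is not yet measured. It carries chloro in place of hydrogen on an aromatic carbon, the same kind of change as that from compound 1 to compound 3, but not the same: there the place is para to a large group, here it is ortho to a chloro group, meta and para to a fused ring, on a fused system. The cores differ by chloro in place of benzoyl on an aromatic carbon. Because a 2.8-fold higher number from compound 1 to compound 3 (0.45 log units; beyond the scatter) was a modest rise, the expectation for compound 4 is a smaller but similar step, a 2.1-fold higher number from compound 2 to compound 4 (0.32 log units; beyond the scatter). Compound 4 is estimated at 2 h, between 1 h and 4 h.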

Compound 4, half-life: 0.917 h
For compound 4 the middle estimate is 2.2-fold (0.34 log units) above the measured one; the whole stated range lies above it.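

In this assay chloro in place of hydrogen on an aromatic carbon did not carry over from one core to the other with the same result: a 2.8-fold higher number from compound 1 to compound 3 (0.45 log units; beyond the scatter) lies beyond the scatter, while a 1.1-fold lower number from compound 2 to compound 4 (0.02 log units; within the scatter) lies within it, so compound 2 and compound 4 cannot be told apart. The two steps differ in the place of the change as well as in the core, and with one step on each core these compounds do not show which of the two matters. Nothing at hand accounts for the difference between the two steps. As far as these compounds go, whether an amine or a methoxy group in place of the added chloro would give a step beyond the scatter remains open.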